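Compound 2 to compound 3: 4-ethylphenyl in place of 3-ethynylphenyl

This account rests on a few compounds, and the source may have more. Where it says the series, first, only, none or still open, it means among the compounds named here.

In a functional assay on HCT-116 cells (Homo sapiens) for antiproliferative activity, read by radiometric assay, with a stated time of 72 h (a higher number here means a weaker inhibitor, a lower number a stronger inhibitor), compound 1 `CCc1cccc(Nc2ncnc3cc(NC(=O)CCCCCCC(=O)NO)sc23)c1` gives 1440 nM and compound 2 `C#Cc1cccc(Nc2ncnc3cc(NC(=O)CCCCCCC(=O)NO)sc23)c1` gives 1010 nM. These two values stand level, with a 1.4-fold lower number from compound 1 to compound 2 (0.15 log units; within the scatter). Next is compound 3 `CCc1ccc(Nc2ncnc3cc(NC(=O)CCCCCCC(=O)NO)sc23)cc1`, which brings (4-ethylphenyl in place of 3-ethynylphenyl on a nitrogen on an aromatic ring). For the measured compounds named here, the only measured step that bears on this is a 1.4-fold lower number from compound 1 to compound 2 (0.15 log units; within the scatter), and it exchanges ethyl for ethynyl. Going by the values given here, no measured compound carries the 4-ethylphenyl group, so that part of the change remains untested. In this assay the expected result is a 1.4-fold higher number from compound 2 to compound 3 (0.14 log units; within the scatter), with no step beyond the scatter foreseen. The estimated value for compound 3 is 1400 nM, with an expected range of 600 nM to 3300 nM.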

Compound 3, half-maximal inhibitory concentration: 2360 nM
For compound 3 the middle estimate is 1.7-fold (0.23 log units) below the measured one, and the stated range covers the measured number.
By their numbers in this assay, from the lowest: compounds 2, 1 and 3 (each within the scatter of the next, the first and the last beyond it).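

In this assay, for the compounds shown here, 4-ethylphenyl in place of 3-ethynylphenyl on the nitrogen gives a 2.3-fold higher number from compound 2 to compound 3 (0.37 log units; beyond the scatter), the first step beyond the scatter, though a modest one. Against 3-ethylphenyl, the same 4-ethylphenyl group gives a 1.6-fold higher number from compound 1 to compound 3 (0.21 log units; within the scatter), so moving the ethyl group alone produces no readable change, and only compound 2 and compound 3 stand apart. Nothing available explains the step from compound 2 to compound 3.

Open, going by these compounds, is how 4-ethynylphenyl would compare with 3-ethynylphenyl and 4-ethylphenyl. Also open, on these data alone, is whether an amine or a carboxylic acid on this phenyl ring would hold these values.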